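The source may report more compounds than this note shows. Statements on the series, on what has been measured and on what is new or still open speak of the compounds shown alone.

Measured in a functional assay on HeLa cells (Homo sapiens) for antiproliferative activity, read by sulforhodamine B assay, with a stated time of 48 h; a lower number here means a stronger inhibitor of growth, a higher number a weaker inhibitor of growth:
Compound 1 `CCCCCc1ccc(-c2cn(CCCN3C(=O)COc4ccccc43)nn2)cc1`: > 100000 nM
Compound 2 `COc1ccc2cc(-c3cn(CCCN4C(=O)COc5ccccc54)nn3)ccc2c1`: > 100000 nM
Compound 3 `O=C1COc2ccccc2N1CCCn1cc(-c2cccnc2)nn1`: > 100000 nM

Each of these entries is a limit of this assay, not a number. Compound 3 stands at that limit, with > 100000 nM. Going by the values given here, compound 1 and compound 2 share it, so the series so far shows (the limit of > 100000 nM in this assay, at which 3 of the 3 values shown sit). Among the compounds with values here, no measured pair gives the size of a step.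

Compound 4 `O=C1COc2ccccc2N1CCCn1cc(C2(O)CCCCC2)nn1` carries 1-hydroxycyclohexyl in place of pyridin-3-yl on an aromatic carbon. The step expected is a number no higher from compound 3 to compound 4 (the limit leaves the size open), and none beyond the scatter of this assay is expected. That expectation rests on compound 3, whose limit is > 100000 nM. For compound 4 the estimated value is 100000 nM, with an expected range of 30000 nM to 100000 nM.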

Compound 4, concentration for 50% growth inhibition: 2000 nM
For compound 4 the middle estimate is 50-fold (1.70 log units) above the measured one; the whole stated range lies above it.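

In this assay, 1-hydroxycyclohexyl in place of pyridin-3-yl gives an at least 50-fold lower number from compound 3 to compound 4 (1.69 log units; beyond the scatter), so this aromatic carbon of the five-membered aromatic ring with 3 nitrogen can carry a group that gives a measurable value on the shared core. Compound 4 is the only compound shown with a number rather than a limit, and only its group has a non-aromatic carbon ring and a hydrogen-bond donor. The other compounds all remain at a limit: the limit of > 100000 nM in this assay, at which 3 of the 4 values shown sit.

Going by these compounds, the step changes the ring and adds the hydroxyl together, and it remains open which of the two matters. A plain cyclohexyl, or an amine in place of the hydroxyl, would separate them.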